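This account rests on a few compounds, and the source may have more. Where it says the series, first, only, none or still open, it means among the compounds named here.

Among the measured compounds shown here, compound 1 `Cc1cc(-c2ccccc2)n(/C(N)=N/S(=O)(=O)c2cc(C)c(Cl)cc2SCc2ccccc2C)n1` is one of two compounds measured in a functional assay on HeLa cells (Homo sapiens) for cytotoxicity, read by MTT assay, with a stated time of 72 h (a higher number here means a weaker inhibitor, a lower number a stronger inhibitor), where compound 1 gives 160000 nM, the higher of the two numbers. Compound 2 `Cc1cc(S(=O)(=O)/N=C(\N)n2nccc2-c2ccccc2)c(SCc2cccc(C(F)(F)F)c2)cc1Cl` differs from it in more than one place and gives 19000 nM in this assay. Compound 3 `Cc1cc(-c2ccccc2)n(/C(N)=N/S(=O)(=O)c2cc(C)c(Cl)cc2SCc2ccc(Cl)cc2)n1` is the untested partner of compound 1: the change is 4-chlorophenyl in place of 2-methylphenyl on a saturated chain carbon bound to a sulfur. For the measured compounds named here, no single-change step has been measured here, so the expected step from compound 1 to compound 3 is uncertain; a small move toward a lower number, possibly within the scatter, is expected, a 1.8-fold lower number from compound 1 to compound 3 (0.25 log units; within the scatter). Compound 3 is estimated to give 90000 nM, between 25000 nM and 300000 nM.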

Compound 3, half-maximal inhibitory concentration: 3000 nM
Estimate against measurement, compound 3: 30-fold (1.48 log units) above, outside the stated range (below it).
By their numbers in this assay, from the lowest: compound 3; then compound 2; then compound 1.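

In this assay, among the compounds shown here, the group on the sulfur turns out to matter far more than the earlier compounds could show: 4-chlorophenyl in place of 2-methylphenyl gives a 53-fold lower number from compound 1 to compound 3 (1.73 log units; beyond the scatter). For the compounds shown here, this is the first single-change step available, so it shows that this position alone can move the number strongly. Nothing available explains why the step is so large.

This one step swaps two features at once, so the chlorine and the methyl cannot be judged separately. As far as these compounds go, a plain benzyl group on the sulfur would help to separate them, and how it would compare remains open.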